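Shortening a Hydroxyalkyl Chain: Plasma Unbound Fraction

This account rests on a few compounds, and the source may have more. Where it says the series, first, only, none or still open, it means among the compounds named here.

The compounds measured so far, with their results in an ADME assay on the whole organism (plasma, Rattus norvegicus) for protein binding, using cassette dosing, at a dose of 1 mg/kg; a lower number here means a smaller unbound share, a higher number a larger unbound share of the compound:

Compound 1, `CC(C)Oc1ccc(Nc2nc(=O)n(CCCO)c(=O)n2Cc2ccc(Cl)cc2)cc1Cl`, gives 0.003.
Compound 2, `CC(C)Oc1ccc(/N=c2\[nH]c(=O)n(CC(C)(C)C(=O)O)c(=O)n2Cc2ccc(Cl)cc2)cc1Cl`, gives 0.003.
Compound 3, `CC(C)Oc1ccc(/N=c2\[nH]c(=O)n(C[C@@H](C)C(=O)O)c(=O)n2Cc2ccc(Cl)cc2)cc1Cl`, gives 0.002.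

Compound 1 stands level with compound 2 at the digits reported, and the two together hold the highest of the three numbers; compound 3 lies a little lower, but that gap is within the scatter, so the three results cannot be ordered with confidence.

Compound 4, `CC(C)Oc1ccc(Nc2nc(=O)n(CCO)c(=O)n2Cc2ccc(Cl)cc2)cc1Cl`, is the next compound to be measured in this assay. It differs from compound 1 by hydroxy in place of hydroxymethyl on a saturated chain carbon, two bonds along the chain from an aromatic nitrogen.

Only one measured step exists among these compounds, a 1.5-fold lower number from compound 2 to compound 3 (0.18 log units; within the scatter). It, too, reshapes a saturated chain hung on a ring nitrogen of the shared core, and it stayed within the scatter. Going by the values given here, no measured step shortens a hydroxyalkyl chain, so the bearing of that single step is indirect. On this basis the change from compound 1 to compound 4 is expected to produce no step beyond the scatter, no change at the digits printed from compound 1 to compound 4 (within the scatter).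

Compound 4 is therefore estimated to give 0.003 in this assay, within a range of 0.0015 to 0.006.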

Compound 4, unbound fraction: 0.001
For compound 4 the middle estimate is 3.0-fold (0.48 log units) above the measured one, and the stated range ends above it.
By their numbers in this assay, from the lowest: compounds 4, 3, 1 and 2 (each within the scatter of the next, the first and the last beyond it).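

In this assay, the change from 3-hydroxypropyl to 2-hydroxyethyl gives the first step beyond the scatter among these compounds (a 3.0-fold lower number from compound 1 to compound 4 (0.48 log units; beyond the scatter)), though a modest one. This shows that the unbound fraction can respond to the length of the hydroxyalkyl chain at this position, on a saturated chain carbon, two bonds along the chain from an aromatic nitrogen, even though the group that leaves and the group that enters have the same hydrogen-bond donor and acceptor counts and neither carries a net charge; the earlier step on a chain at a ring nitrogen (a 1.5-fold lower number from compound 2 to compound 3 (0.18 log units; within the scatter)) had stayed within the scatter. Nothing shown here accounts for the lower number with the shorter chain.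

The compounds shown hold a single pair that differs in hydroxyalkyl chain length, so they leave open whether the number follows chain length at all, or whether a longer chain such as 4-hydroxybutyl or a shorter hydroxymethyl would extend the step. They also leave open how an amine or a methyl ether at the end of this chain would read in this assay.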